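From 3,4-dichlorophenyl to 2,4-dihydroxyphenyl in an antiproliferative series

A few compounds are considered here, and "the series" means these few. Any claim that something is new, unique, unknown or untested is made for them only; others in the source may bear on it.

Measured so far in a functional assay on A549 cells (Homo sapiens) for antiproliferative activity, read by MTT assay, with a stated time of 72 h; on this read-out higher numbers stand for weaker inhibition and lower numbers for stronger inhibition:
compound 1 `O=C(N/N=C/c1cccc(Br)c1)Nc1ccc(Oc2ccnc3[nH]ccc23)c(F)c1` gives 2220 nM
compound 2 `O=C(N/N=C/c1ccc(F)cc1)Nc1ccc(Oc2ccnc3[nH]ccc23)c(F)c1` gives 680 nM
compound 3 `O=C(N/N=C/c1ccc(Cl)c(Cl)c1)Nc1ccc(Oc2ccnc3[nH]ccc23)c(F)c1` gives 2650 nM

Compound 3 shares the weak end of this small set with compound 1, and the gap there is a 1.2-fold higher number from compound 1 to compound 3 (0.08 log units; within the scatter), which lies within the scatter. The clear separations are a 3.3-fold lower number from compound 1 to compound 2 (0.51 log units; beyond the scatter) and a 3.9-fold higher number from compound 2 to compound 3 (0.59 log units; beyond the scatter), both modest and beyond the scatter.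

The next compound, compound 4 `O=C(N/N=C/c1ccc(O)cc1O)Nc1ccc(Oc2ccnc3[nH]ccc23)c(F)c1`, has not yet been measured. It differs from compound 3 in one place: 2,4-dihydroxyphenyl in place of 3,4-dichlorophenyl on a carbon with a double bond to nitrogen. Going by the values given here, no measured compound carries a hydroxy group, so the three steps bear on this change only loosely. They show that exchanges at this place have so far stayed modest, and a step of similar size is the most the data suggest in this assay. The expectation leans towards a lower number, as compound 3 already sits at the weak end and compound 2 reaches 680 nM with a change at this same place. The expected step is a 1.7-fold lower number from compound 3 to compound 4 (0.22 log units; within the scatter), and this is an uncertain estimate. For compound 4 the estimated value is 1600 nM, with an expected range from 500 nM to 5000 nM.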

Compound 4, half-maximal inhibitory concentration: 5840 nM
Estimate against measurement, compound 4: 3.7-fold (0.56 log units) below; measured number above the stated range.
By their numbers in this assay, from the lowest: compound 2; then compounds 1 and 3 (each within the scatter of the next); then compound 4.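

In this assay, going by these compounds alone, 2,4-dihydroxyphenyl is the only group among the four at this place that carries hydrogen-bond donors and acceptors, and it does not bring the number down: in place of 3,4-dichlorophenyl it gives a 2.2-fold higher number from compound 3 to compound 4 (0.34 log units; beyond the scatter), in place of 3-bromophenyl it gives a 2.6-fold higher number from compound 1 to compound 4 (0.42 log units; beyond the scatter), and in place of 4-fluorophenyl it gives an 8.6-fold higher number from compound 2 to compound 4 (0.93 log units; beyond the scatter). All three steps go the same way and lie beyond the scatter, so compound 4 holds the highest number of the set, and the range of values at this place is wider than the halogen-bearing groups alone showed. Nothing at hand accounts for the higher number with the two hydroxy groups.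

The compounds shown leave open whether a phenyl ring with a single hydroxy group would follow compound 4 or stay closer to compound 2, and whether methoxy groups in place of the hydroxy groups would give a similar number. They also leave open how an amine or a carboxylic acid on the phenyl ring would read in this assay.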